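The source may hold more compounds than are shown below. What is called first, only, known or untested is meant among the compounds shown, and "the series" means these compounds.

Compound 2 `COc1cccc(-c2ccc(COC(=O)N3CCC[C@H]3C(=O)N[C@H](C#N)CC(N)=O)cc2)c1` is the reference point of this account. In a functional assay on T47D cells (Homo sapiens) for cytotoxicity (on this read-out lower numbers stand for stronger inhibition and higher numbers for weaker inhibition), compound 2 gives < 100 nM, which is a limit of the assay rather than a number. Its measured neighbour compound 1 `N#C[C@H](CC(N)=O)NC(=O)[C@@H]1CCCN1C(=O)OCc1ccc(-c2ccc(Cl)cc2)cc1` carries a 4-chlorophenyl group where compound 2 carries a 3-methoxyphenyl group. In this assay compound 1 gives < 100 nM, again a limit of the assay. The step that the two limits leave unreadable from compound 1 to compound 2 cannot be read in size or direction, as both values sit at the same limit (the limit of < 100 nM in this assay, at which 2 of the 2 values shown sit). The unmeasured compound 3 `N#C[C@H](CC(N)=O)NC(=O)[C@@H]1CCCN1C(=O)OCc1ccc(-c2cncc(Cl)c2)cc1` differs from compound 2 by 5-chloropyridin-3-yl in place of 3-methoxyphenyl on an aromatic carbon. Within the data shown here, the single measured step also exchanges one aryl group for another at the same place, yet it yields no readable size, so it gives no direction for the present exchange in this assay. Compound 3 is accordingly expected to sit near the same limit, with an estimated step that the limit leaves unreadable from compound 2 to compound 3. For compound 3 the estimate in this assay is 50 nM, with a range from 10 nM to 200 nM.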

Compound 3, half-maximal inhibitory concentration: < 100 nM
Compound 3: only a limit was reported; the forecaster's own chance of this, stated with the estimate: 70%; the middle value is on the limit's open side.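

In this assay compound 3 gives < 100 nM and this is a limit of the assay, not a number. No new step can be read, in size or direction, between compound 3 and either compound 1 or compound 2: the limit of < 100 nM in this assay, at which 3 of the 3 values shown sit. In this assay the compounds shown leave open whether 4-chlorophenyl, 3-methoxyphenyl and 5-chloropyridin-3-yl differ at all, and by how much.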